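Amide replacement on the chlorophenyl-isoxazole series: expected response

A few compounds are considered here, and "the series" means these few. Any claim that something is new, unique, unknown or untested is made for them only; others in the source may bear on it.

Two compounds of the series have been run in a functional assay on HEK293 cells for agonist activity at growth hormone secretagogue receptor type 1 (Homo sapiens), read by HTRF and inositol phosphate accumulation, with a stated time of 90 min, in the presence of a further agent that is not named here; on this read-out higher numbers stand for larger maximal responses and lower numbers for smaller maximal responses. Compound 1 `Cc1ccc2[nH]c(C(=O)N[C@H]3CN(S(=O)(=O)c4ccccc4)C[C@@H]3C(=O)NC[C@@H]3CCCN3C)cc2c1` reaches 87% in this assay. Compound 2 `O=C(N[C@H]1CN(S(=O)(=O)c2ccccc2)C[C@@H]1C(=O)N1C[C@H]2CCNC[C@H]21)c1cc(-c2ccccc2Cl)on1` reaches 98% in this assay, the higher of the two numbers; the gap to compound 1 lies beyond the usual scatter, so compound 2 stands above compound 1 on what has been measured.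

Compound 3 `CC(=O)N1CCC[C@H](NC(=O)[C@H]2CN(S(=O)(=O)c3ccccc3)C[C@@H]2NC(=O)c2cc(-c3ccccc3Cl)on2)C1` has not yet been run. It differs from compound 2 at one position only, on a carbonyl carbon whose other neighbours are a saturated ring carbon: a group of 10 heavy atoms (7 carbon, 2 nitrogen, 1 oxygen; one six-membered non-aromatic ring with 1 hetero atom) in place of a group of 8 heavy atoms (6 carbon, 2 nitrogen; one four-membered non-aromatic ring with 1 hetero atom, one six-membered non-aromatic ring with 1 hetero atom), on a carbonyl carbon

For the measured compounds named here, no pair of measured compounds shows a step at this position, so no measured step can be borrowed. The change keeps the chlorophenyl-isoxazole part of compound 2 and alters only the amide partner. The step from compound 2 to compound 3 is expected to be small, downward if anything, and likely within the scatter: a number 8 percentage points lower from compound 2 to compound 3 (within the scatter). Compound 3 is estimated at 90% in this assay, within a range of 75% to 105%, because the maximal response of compound 2 at 98% leaves little room upward while compound 1 at 87% shows the series can sit lower.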

Compound 3, largest response reached (Emax), in percent of the reference or control that the assay uses in the growth hormone secretagogue receptor type 1 assay: 91%
Compound 3: the middle estimate sits 1 percentage points below what was measured; the measured number falls inside the stated range.
By their numbers in the growth hormone secretagogue receptor type 1 assay, from the lowest: compounds 1, 3 and 2 (each within the scatter of the next, the first and the last beyond it).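

For the compounds shown here, in the growth hormone secretagogue receptor type 1 assay, the first step at this position is a number 7 percentage points lower from compound 2 to compound 3 (within the scatter), so a group of 10 heavy atoms with one six-membered non-aromatic ring takes the place of the two-ring group of 8 heavy atoms, on a carbonyl carbon, with no change in maximal response beyond the scatter. In a physicochemical assay for lipophilicity, measured as octanol-water partition, at pH 7.4 (a higher number here means a more lipophilic compound, a lower number a more polar compound), compound 2 gives 1.7 and compound 3 gives 3.5. The same replacement therefore moves lipophilicity by a large step while the maximal response stays within the scatter, which shows that in this pair the two read-outs do not move together: the measured distribution coefficient of compound 2, 1.7, and of compound 3, 3.5, a number 1.80 log units higher (beyond the scatter)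

The step changes the ring count, the heavy-atom count and the oxygen count at once, so the pair cannot assign the shift in lipophilicity to any one of these features. Still open, from the compounds shown here alone, is whether the maximal response holds when a carboxylic acid, an open-chain amine or a longer chain stands on this carbonyl carbon, and whether the same replacement behaves alike with the indole-bearing part of compound 1.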